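Swapping a fused ring for a small imidazole

The compounds below may be only part of what the source reports. "The series", "measured", "known", "first", "only" and "open" are said of these compounds alone.

Compound 1 `CCOc1cc(C(=O)Nc2ccc(Cl)c(-c3nc4ccccc4s3)c2)cc(OCC)c1OCC` was tested in a functional assay on Shh Light II cells for inhibition of Sonic hedgehog protein (Mus musculus), read by reporter gene assay, with a stated time of 48 h, in the presence of a further agent that is not named here (on this read-out higher numbers stand for weaker inhibition and lower numbers for stronger inhibition), and gave "not active" (no number reported), so no single number places it on the scale. A related amide, compound 2 `O=C(Nc1ccc(Cl)c(-c2nc3ccccc3[nH]2)c1)c1cccc(C(F)(F)F)c1`, differs in both its ring and its acid part, and in this assay compound 2 gives 119 nM. Compound 3 `CCOc1cc(C(=O)Nc2ccc(Cl)c(-c3ncc[nH]3)c2)cc(OCC)c1OCC` arises from compound 1 by 1H-imidazol-2-yl in place of 1,3-benzothiazol-2-yl on an aromatic carbon. Within the data shown here, no measured pair shows this exact step, so its size is unknown; the ring that enters is much smaller and carries a hydrogen-bond donor. Compound 3 is expected to give about 2500 nM, within a range from 300 nM to 20000 nM, with a fair chance of again reading as inactive.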

Compound 3, half-maximal inhibitory concentration: "not active" (no number reported)
No number was reported for compound 3; no gap can be computed for the estimate.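

Compound 1 and compound 3 both gave no number, so no step can be read between them. The compounds shown leave open how far 1H-imidazol-2-yl in place of 1,3-benzothiazol-2-yl changes inhibition. No supporting evidence bears on this result.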